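The source may hold more compounds than are shown below. What is called first, only, known or untested is meant among the compounds shown, and "the series" means these compounds.

Measured so far in a functional assay on SMMC-7721 cells (Homo sapiens) for antiproliferative activity; on this read-out lower numbers stand for stronger inhibition and higher numbers for weaker inhibition:
- compound 1 `CCn1cc(-c2nnc(SCc3nnc(-c4ccc(F)cc4)o3)[nH]2)c(=O)c2cc(F)c(N3CCN(C)CC3)cc21` gives 3800 nM
- compound 2 `CCn1cc(-c2nc(SCc3nnc(-c4ccc(F)cc4)o3)n(CN(C)C)n2)c(=O)c2cc(F)c(N3CCN(C)CC3)cc21` gives 1500 nM

Of these two compounds, compound 1 has the higher number and so the weaker inhibition, and compound 2 lies below it by more than the scatter. The next compound to be tested is compound 3 `CCn1cc(-c2nnc(SCc3nnc(-c4ccccc4OC)o3)[nH]2)c(=O)c2cc(F)c(N3CCN(C)CC3)cc21`, which keeps the core of compound 1 and changes one group. On an aromatic carbon of a five-membered aromatic ring with 2 nitrogen and 1 oxygen, 2-methoxyphenyl stands in place of 4-fluorophenyl (2-methoxyphenyl in place of 4-fluorophenyl on an aromatic carbon). For the measured compounds named here, no measured pair here shows this exchange, so the data do not size it directly. In this assay, from the compounds shown here alone, no step beyond the scatter is expected, and the direction stays open, with only a slight lean toward a lower number. The estimate is therefore anchored on compound 1 at 3800 nM and carries a wide range. The expected change is a 1.3-fold lower number from compound 1 to compound 3 (0.10 log units; within the scatter), which lies within the scatter. For compound 3 the estimated value is 3000 nM, with an expected range from 1000 nM to 9000 nM.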

Compound 3, half-maximal inhibitory concentration: 3800 nM
The estimate for compound 3 lay 1.3-fold (0.10 log units) below the measured number; measured number inside the range.
By their numbers in this assay, from the lowest: compound 2; then compounds 1 and 3 (each within the scatter of the next).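

In this assay, the exchange of 4-fluorophenyl for 2-methoxyphenyl on an aromatic carbon of the five-membered aromatic ring with 2 nitrogen and 1 oxygen gives no change at the digits printed from compound 1 to compound 3 (within the scatter), the only step at this position among the compounds shown. The read-out therefore does not separate these two groups on the core of compound 1, even though 2-methoxyphenyl has 8 heavy atoms and 1 hydrogen-bond acceptor, while 4-fluorophenyl has 7 heavy atoms and 0 hydrogen-bond acceptors. Nothing measured here bears on why the two groups read alike.

This single pair changes both the substituent and where it sits on the phenyl ring, so it cannot show how each contributes; unsubstituted phenyl, 2-fluorophenyl and 4-methoxyphenyl would be needed to separate them, and a phenyl ring carrying an amine or a carboxylic acid would test a wider range of groups. It also leaves open whether 2-methoxyphenyl and 4-fluorophenyl would still read alike with the dimethylaminomethyl group of compound 2 in place.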